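Cyano for difluoromethyl on the anilide ring

A few compounds are considered here, and "the series" means these few. Any claim that something is new, unique, unknown or untested is made for them only; others in the source may bear on it.

Compound 1 `NS(=O)(=O)CC(=O)NCCSc1nonc1/C(=N/O)Nc1cccc(C(F)F)c1` gives only a limit in an ADME assay on isolated protein for pharmacokinetics, with UDP-glucuronosyltransferase 1A9 (Homo sapiens) as the target, read by LC-MS, with a stated time of 60 min, at 37 degrees C, tested at 1 uM, in the presence of a further agent that is not named here; a lower number here means that the compound disappears faster, a higher number that the compound lasts longer: > 3 h.
Compound 2 `O=C(NCCSc1nonc1/C(=N/O)Nc1ccc(F)c(C(F)F)c1)C1CS(=O)(=O)C1` likewise gives only a limit in this assay: > 3 h.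

Compound 1 therefore stands at the limit of this assay, and the other measured value is a limit too, as the limit of > 3 h in this assay, at which 2 of the 2 values shown sit, shows. Compound 3 `N#Cc1cccc(N/C(=N\O)c2nonc2SCCNC(=O)CS(N)(=O)=O)c1` carries the change (cyano in place of difluoromethyl on an aromatic carbon), cyano in place of difluoromethyl on an aromatic carbon. Among the compounds with values here, no measured step covers this change, so no size beyond the scatter is expected in this assay; the expected step that the limit leaves unreadable from compound 1 to compound 3 is taken as none. Compound 3 is thus expected to give about 4 h, between 2 h and 8 h, most likely again as a limit.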

Compound 3, half-life: > 3 h
Compound 3: no number, only a limit; the forecaster's own chance of this, stated with the estimate: 75%; the middle value lies beyond the limit too.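

Within the data shown here, compound 1 and compound 3 both give only a limit, so no step between them can be read: the limit of > 3 h in this assay, at which 3 of the 3 values shown sit.

The compounds shown leave open how long each lasts in this assay and whether cyano in place of difluoromethyl shifts the half-life at all.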